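The source may report more compounds than this note shows. Statements on the series, on what has been measured and on what is new or still open speak of the compounds shown alone.

Measured compounds in an assay on membranes from liver for displacement of a labelled ligand from Sigma non-opioid intracellular receptor 1 (Rattus norvegicus); on this read-out lower numbers stand for stronger inhibition and higher numbers for weaker inhibition:
- compound 1 `O=c1oc2ccccc2n1CC1CCN(Cc2ccccc2)CC1` gives 3.6 nM
- compound 2 `O=c1oc2ccccc2n1CC1CCN(Cc2ccc(Cl)cc2)CC1` gives 0.1 nM
- compound 3 `Cc1ccc(CN2CCC(Cn3c(=O)oc4ccccc43)CC2)c(C)c1` gives 30 nM

Among these three, compound 3 stands at the highest number, with compound 1 nearest and compound 2 furthest away. The step from compound 1 to compound 2 was a 36-fold lower number from compound 1 to compound 2 (1.56 log units; beyond the scatter), the step from compound 1 to compound 3 was an 8.3-fold higher number from compound 1 to compound 3 (0.92 log units; beyond the scatter), and the step from compound 2 to compound 3 was a 300-fold higher number from compound 2 to compound 3 (2.48 log units; beyond the scatter).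

The unmeasured compound 4 `Cc1cc(C)c(CN2CCC(Cn3c(=O)oc4ccccc43)CC2)c(C)c1` differs from compound 3 by methyl in place of hydrogen on an aromatic carbon; read one bond further out, the change is 2,4-dimethylphenyl to 2,4,6-trimethylphenyl. Among the compounds with values here, no measured pair shows a methyl entering ortho to a large group and meta to two methyl groups, so the step has no direct precedent. The only bearing comes from the steps from compound 1 to compound 3 and from compound 2 to compound 3, in which the dimethyl substitution gave higher numbers than phenyl or 4-chlorophenyl. A third methyl is therefore expected to leave the number where it is or push it somewhat higher, with the step of a 1.7-fold higher number from compound 3 to compound 4 (0.22 log units; within the scatter) expected to be small and uncertain in this assay. Compound 4 is estimated at 50 nM, in a range from 12 nM to 250 nM.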

Compound 4, inhibition constant: 6230 nM
The estimate for compound 4 lay 120-fold (2.10 log units) below the measured number; measured number outside the range, above it.
By their numbers in this assay, from the lowest: compound 2; then compound 1; then compound 3; then compound 4.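

In this assay, a single methyl in place of hydrogen on an aromatic carbon, ortho to a large group and meta to two methyl groups, produced a 210-fold higher number from compound 3 to compound 4 (2.32 log units; beyond the scatter) and so moved the number further than the change from phenyl to 2,4-dimethylphenyl, which gave an 8.3-fold higher number from compound 1 to compound 3 (0.92 log units; beyond the scatter). Within the data shown here, the 2,4,6-trimethylphenyl compound also stands far from the two simpler compounds, with a 1700-fold higher number from compound 1 to compound 4 (3.24 log units; beyond the scatter) and a 62000-fold higher number from compound 2 to compound 4 (4.79 log units; beyond the scatter), so at this place on the ring the series is highly sensitive to one added methyl, and the earlier compounds gave no sign of a change this large from so small a group. Nothing at hand gives a reason for the size of this step.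

The compounds shown leave open whether a fluoro, a methoxy or an ethyl group in the same place, ortho to a large group, would give a step of similar size. They also leave open whether a lone methyl at that place on an otherwise unsubstituted phenyl, or on the 4-chlorophenyl of compound 2, would move the number as far as it did in compound 4.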